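Aryl swap on the amide-type nitrogen of compound 3

The source may report more compounds than this note shows. Statements on the series, on what has been measured and on what is new or still open speak of the compounds shown alone.

Compound 1 `Cc1ccc(S(=O)(=O)Nc2cccc(-c3nc(-c4ccc(NC(=O)c5cccnc5)cc4Cl)no3)c2)cc1` carries a (4-methylphenyl)sulfonyl group on the ring nitrogen. In a functional assay on MDA-MB-231 cells (Homo sapiens) for antiproliferative activity, read by MTT assay, with a stated time of 72 h (on this read-out lower numbers stand for stronger inhibition and higher numbers for weaker inhibition), compound 1 reaches only the assay limit, > 10000 nM. Compound 2 `O=C(Nc1cccc(-c2nc(-c3ccc(NC(=O)c4cccnc4)cc3Cl)no2)c1)Nc1cccc(C(F)(F)F)c1` gives 1900 nM in this assay. Compound 3 `COc1ccc(NC(=O)Nc2cccc(-c3nc(-c4ccc(NC(=O)c5cccnc5)cc4Cl)no3)c2)cc1` gives 3000 nM in this assay; this is the higher of the two proper numbers shown, though the gap to compound 2 is small: a 1.6-fold higher number from compound 2 to compound 3 (0.20 log units; within the scatter). The other measured step, an at least 3.3-fold lower number from compound 1 to compound 3 (0.52 log units; beyond the scatter), is of a different kind, as it exchanges the whole group on the ring nitrogen and starts from a limit (the limit of > 10000 nM in this assay, at which 1 of the 3 values shown sits).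

Compound 4 `C#Cc1cccc(NC(=O)Nc2cccc(-c3nc(-c4ccc(NC(=O)c5cccnc5)cc4Cl)no3)c2)c1` differs from compound 3 in one place: 3-ethynylphenyl in place of 4-methoxyphenyl on an amide-type nitrogen. Going by the values given here, the step that bears on this is the one from compound 2 to compound 3, an aryl exchange on the same amide-type nitrogen that stayed within the scatter. On that basis the expected step of a 1.2-fold lower number from compound 3 to compound 4 (0.08 log units; within the scatter) in this assay is none beyond the scatter, in either direction. Compound 4 is therefore expected to give about 2500 nM in this assay, with a likely range from 900 nM to 7000 nM.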

Compound 4, half-maximal inhibitory concentration: > 10000 nM
Compound 4: a limit, no number; the forecaster's own chance of this, stated with the estimate: 10%; at least 4.0-fold (0.60 log units) between middle value and limit.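

On this amide-type nitrogen, the choice of aryl group can matter beyond the scatter: 3-ethynylphenyl in place of 4-methoxyphenyl gives an at least 3.3-fold higher number from compound 3 to compound 4 (0.52 log units; beyond the scatter) in this assay, whereas the earlier aryl exchange on the same nitrogen gave a 1.6-fold higher number from compound 2 to compound 3 (0.20 log units; within the scatter). Ethynyl in place of trifluoromethyl on an aromatic carbon, a change of that one group only, gives an at least 5.2-fold higher number from compound 2 to compound 4 (0.72 log units; beyond the scatter), so this single exchange is enough to take the read-out from a proper number to the assay limit. Both steps give only a lower bound on their size, and the step from compound 1 to compound 4 cannot be read, because compound 1 and compound 4 both sit at a limit: the limit of > 10000 nM in this assay, at which 2 of the 4 values shown sit.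

On these data alone, how far compound 4 actually lies past that limit stays open, so the size of the change cannot be set against other exchanges. Also open, as far as these compounds go, is whether an aryl group carrying an amine or a carboxylic acid, such as 3-aminophenyl or 3-carboxyphenyl, on this nitrogen would stay in the range of compound 2 and compound 3 or fall to the limit with compound 4.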